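A few compounds are considered here, and "the series" means these few. Any claim that something is new, unique, unknown or untested is made for them only; others in the source may bear on it.

Values measured in a functional assay on HL-60 cells (Homo sapiens) for antiproliferative activity, read by MTT assay, with a stated time of 48 h; on this read-out lower numbers stand for stronger inhibition and higher numbers for weaker inhibition:
- Compound 1 `COC/C1=C/C[C@](C)(CCC=C(C)C)/C=C/[C@@H](OC(=O)C=C(C)C)[C@](C)(O)/C=C/C1=O`: 3070 nM
- Compound 2 `CC(=O)O[C@]1(C)/C=C/C(=O)/C(CO)=C\C[C@](C)(CCC=C(C)C)/C=C/[C@H]1OC(=O)C=C(C)C`: 2370 nM
- Compound 3 `CO[C@]1(C)/C=C/C(=O)/C(CO)=C\C[C@](C)(CCC=C(C)C)/C=C/[C@H]1OC(=O)C=C(C)C`: 14300 nM

Compound 1, at 3070 nM, lies within the usual scatter of compound 2, at 2370 nM. Compound 3, at 14300 nM, gives a clearly higher number, which means weaker inhibition.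

The next compound to be tested is compound 4 `CC(C)=CCC[C@]1(C)/C=C/[C@@H](OC(=O)C=C(C)C)[C@](C)(O)/C=C/C(=O)/C(CN2CCCC2)=C\C1`. It keeps the core of compound 1 but carries pyrrolidin-1-yl in place of methoxy on a saturated chain carbon bound to a double-bonded ring carbon.

Among the compounds with values here, no measured pair makes this swap, so the data give no direct guide to its direction. Within the data shown here, the only measured step, a 6.0-fold higher number from compound 2 to compound 3 (0.78 log units; beyond the scatter), is a different change: methyl in place of acetyl on an oxygen on a saturated carbon. It shows only that one small edit to this core can move the number beyond the scatter, and it offers a rough scale for such a move.

With no direction to go on, the expected outcome in this assay is no clear shift, though a move of similar size either way remains possible. The estimate amounts to a 1.2-fold lower number from compound 1 to compound 4 (0.09 log units; within the scatter), an expected step that stays small. For compound 4 the estimated value is 2500 nM, with an expected range from 700 nM to 9000 nM.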

Compound 4, half-maximal inhibitory concentration: 160 nM
Estimate against measurement, compound 4: 16-fold (1.19 log units) above; measured number outside the range, below it.
By their numbers in this assay, from the lowest: compound 4; then compounds 2 and 1 (each within the scatter of the next); then compound 3.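

In this assay, the change from methoxy to pyrrolidin-1-yl gives a 19-fold lower number from compound 1 to compound 4 (1.28 log units; beyond the scatter) and so shows that the group on this saturated chain carbon bound to a double-bonded ring carbon can strongly affect the read-out. Within the data shown here, the earlier compounds could not show this, since their only measured step, a 6.0-fold higher number from compound 2 to compound 3 (0.78 log units; beyond the scatter), belongs to a different change, on an oxygen on a saturated carbon. Here the direction is towards stronger inhibition, but nothing measured for these compounds accounts for the gain, so the data record the effect without explaining it.

On these data alone, with a single replacement at this place, it remains open whether the gain needs the pyrrolidin-1-yl ring itself or would also appear with another amine, such as the open-chain dimethylamino group or the larger piperidin-1-yl and morpholin-4-yl rings. As far as these compounds go, it is also open whether pyrrolidin-1-yl would have a similar effect on the core of compound 2 or compound 3, where an acetyl or methyl group sits on the oxygen on a saturated carbon.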